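Branching of the ester and thioester chains in a small series

The source may hold more compounds than are shown below. What is called first, only, known or untested is meant among the compounds shown, and "the series" means these compounds.

Measured compounds:
- compound 1, `CCCOC(=O)C1=C(C)NC(=S)NC1c1ccco1`: 1%
- compound 2, `CC1=C(C(=O)OCC(C)C)C(c2ccco2)NC(=S)N1`: 7%
- compound 3, `CCSC(=O)C1=C(C)NC(=O)NC1c1ccsc1`: 11%

All three were tested in an assay on membranes from CHO cells for displacement of a labelled ligand from adenosine receptor A1 (Homo sapiens), read by scintillation counting, with a stated time of 60 min, tested at 1 uM; on this read-out lower numbers stand for less inhibition and higher numbers for more inhibition at the one concentration tested (going by the name of the read-out). Compound 1 and compound 2 share a core and differ in one place, (methyl in place of hydrogen on a saturated chain carbon bound to two saturated chain carbons). The step of a number 6 percentage points higher from compound 1 to compound 2 (within the scatter). Compound 3 carries a different core; the difference between the two cores is not broken down here. Compound 3 gives the highest of the three numbers, but its gaps to compound 2 and to compound 1 are both within the scatter, so the three measured values cannot be told apart in this assay.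

Compound 4, `CC1=C(C(=O)SC(C)C)C(c2ccsc2)NC(=O)N1`, has not yet been measured. It differs from compound 3 in one place, (methyl in place of hydrogen on a saturated chain carbon bound to a saturated chain carbon and a sulfur). This is the same kind of change as that from compound 1 to compound 2, but not the same: there the carbon was bound to two saturated chain carbons, here it is bound to a saturated chain carbon and a sulfur. Within the data shown here, the only precedent for this kind of change is the step from compound 1 to compound 2, which stayed within the scatter.

The step from compound 3 to compound 4 is therefore expected to be small, a number 4 percentage points higher from compound 3 to compound 4 (within the scatter), resting on the near-flat result a number 6 percentage points higher from compound 1 to compound 2 (within the scatter) and on the measured value of compound 3, 11%. Compound 4 is expected to show about 15% in this assay, plausibly between 3% and 30%.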

Compound 4, a percentage reported as inhibition, at one concentration (the size of the read-out at that concentration, not a potency): 24%
For compound 4 the middle estimate is 9 percentage points below the measured one; the range from low to high includes it.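

In this assay, going from ethylsulfanyl to isopropylsulfanyl gives a number 13 percentage points higher from compound 3 to compound 4 (beyond the scatter), so on this core the added methyl has a measurable effect on the read-out, though a modest one. The same kind of change on the other core gives a step that does not clear the scatter, yet the two steps themselves cannot be told apart: the same change on two cores in this assay, a number 6 percentage points higher (within the scatter) from compound 1 to compound 2 and a number 13 percentage points higher (beyond the scatter) from compound 3 to compound 4, 7 percentage points apart, within the scatter of two such steps This supports carrying the change between these two cores only loosely, as a step of similar size; it does not show that the size is independent of the core, and with a single pair on each core, whose methyl sits on differently bound carbons (one bound to two saturated chain carbons, the other to a saturated chain carbon and a sulfur), no general rule for the series follows.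

The compounds shown leave open how far the chain can be extended or branched, for example with a tert-butyl group or a longer chain such as hexyl on the ester or thioester. They also leave open what a carboxylic acid or an amide would give in that place, and whether ester and thioester differ on a single core, as all values come from one concentration only.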